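The source may report more compounds than this note shows. Statements on the series, on what has been measured and on what is new or still open speak of the compounds shown alone.

Compound 2, with the structure `NS(=O)(=O)c1ccc(N2N=C(c3ccc(Oc4ccccc4)cc3)CC2c2ccccc2)cc1`, stands at the higher of the two numbers measured in an ADME assay on BHK-21 cells (Mesocricetus auratus) for cytotoxicity, read by MTT assay, with a stated time of 72 h (a higher number here means that more compound is tolerated, a lower number that less compound is tolerated), where compound 2 gives 11000 nM. Within the data shown here, its only neighbour is compound 1, with the structure `NS(=O)(=O)c1ccc(N2N=C(c3ccc(Oc4ccccc4)cc3)CC2c2ccc(F)cc2)cc1`, which in this assay gives 8000 nM. The step between them, a 1.4-fold higher number from compound 1 to compound 2 (0.14 log units; within the scatter), lies within the scatter, so the two compounds are not told apart on this assay.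

Compound 3, with the structure `Cc1ccc(C2CC(c3ccc(Oc4ccccc4)cc3)=NN2c2ccc(S(N)(=O)=O)cc2)cc1`, differs from compound 2 by methyl in place of hydrogen on an aromatic carbon. Among the measured compounds shown here, the one measured step that bears on this change is the exchange at the same place on the same ring, the one that reads a 1.4-fold higher number from compound 1 to compound 2 (0.14 log units; within the scatter); it was within the scatter. For the measured compounds named here, there is no measured step that introduces a methyl, so the expectation rests on that single comparison alone. On that basis the step from compound 2 to compound 3 is expected to be small, a 1.1-fold lower number from compound 2 to compound 3 (0.04 log units; within the scatter), with no direction that the data can support beyond the scatter. Compound 3 is therefore expected to give about 10000 nM in this assay, with a range from 5000 nM to 20000 nM.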

Compound 3, half-maximal cytotoxic concentration: 8000 nM
Estimate against measurement, compound 3: 1.3-fold (0.10 log units) above; the measured number falls inside the stated range.
By their numbers in this assay, from the lowest: compounds 1, 3 and 2 (each within the scatter of the next).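

Among these compounds, with compound 3, the aromatic carbon para to a large group carries a carbon substituent for the first time, alongside the hydrogen and fluoro already seen there. In this assay, putting methyl in place of hydrogen gives a 1.4-fold lower number from compound 2 to compound 3 (0.14 log units; within the scatter) and putting methyl in place of fluoro gives no change at the digits printed from compound 1 to compound 3 (within the scatter) at this same place. Among the compounds shown here, both steps lie within the scatter, so the single earlier exchange of hydrogen for fluoro now has two more beside it, and hydrogen, fluoro and methyl at this place are not told apart on this read-out.

The compounds shown leave open whether any group at this place can move the number beyond the scatter, for which an amine, a carboxylic acid or a longer chain such as butyl would be a much sterner test than these small groups. They also leave open whether the same flat picture would hold for these three groups if the shared core were changed elsewhere. Nothing shown offers any account of these numbers.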